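A few compounds are considered here, and "the series" means these few. Any claim that something is new, unique, unknown or untested is made for them only; others in the source may bear on it.

Of the compounds shown here, three have been tested in a functional assay on the whole organism with Mus musculus as the target (a higher number here means that more compound is needed for the effect, a lower number that less compound is needed), and a fourth is still to come. Compound 1 `O=C(/C=C1\CCc2cc(F)cc(F)c21)NC1CC1` carries a cyclopropyl on its amide-type nitrogen; in this assay compound 1 gives 69 mg/kg. Compound 2 `NC(=O)/C=C1\CCc2c(F)cc(F)cc21` has a free amide nitrogen on a core in which the same atoms are joined differently from compound 3, and in this assay compound 2 gives 69 mg/kg. Compound 3 `NC(=O)/C=C1\CCc2cc(F)cc(F)c21` shares the core of compound 1; in this assay compound 3 gives 44 mg/kg. The difference between the two cores is not broken down here.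

Compound 1 differs from compound 3 by cyclopropyl in place of hydrogen on an amide-type nitrogen. This step, a 1.6-fold higher number from compound 3 to compound 1 (0.20 log units; within the scatter), lies within the scatter, so compounds 1 and 3 are best read as level.

Compound 4 `O=C(/C=C1\CCc2c(F)cc(F)cc21)NC1CC1` is the unmeasured compound. For the measured compounds named here, it differs from compound 2 by cyclopropyl in place of hydrogen on an amide-type nitrogen, the same change as the one from compound 3 to compound 1, made on the same kind of nitrogen and on the core of compound 2. Since that change left the number essentially unmoved in a 1.6-fold higher number from compound 3 to compound 1 (0.20 log units; within the scatter), and since compound 2 sits at 69 mg/kg, a similar outcome is estimated here. The expected step is a 1.3-fold higher number from compound 2 to compound 4 (0.12 log units; within the scatter). Compound 4 is therefore expected to give about 90 mg/kg in this assay, with a plausible range from 45 mg/kg to 180 mg/kg.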

Compound 4, dose for half-maximal effect: 62 mg/kg
The estimate for compound 4 lay 1.5-fold (0.16 log units) above the measured number; low and high end bracket the measured number.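

On the core shared by compound 2 and compound 4, cyclopropyl in place of hydrogen on an amide-type nitrogen gives, in this assay, a 1.1-fold lower number from compound 2 to compound 4 (0.05 log units; within the scatter). Set beside the same change on the other core, this step cannot be told apart from the earlier one: the same change on two cores in this assay, a 1.6-fold higher number (0.20 log units; within the scatter) from compound 3 to compound 1 and a 1.1-fold lower number (0.05 log units; within the scatter) from compound 2 to compound 4, 1.7-fold (0.24 log units) apart, within the scatter of two such steps. Across these four compounds, then, the change carries over in a modest sense: on both cores it leaves the number within the usual scatter, so neither core gives a sign of responding to it differently, but this rests on only two pairs and does not show that the change would behave the same way on any further core, nor does a small step on two cores say anything about other groups at this nitrogen.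

The compounds shown carry only hydrogen or cyclopropyl on this nitrogen, so it remains open whether a methyl, a longer chain such as butyl, or a chain ending in an amine or a carboxylic acid would move the number beyond the scatter on either core. Also open, from the compounds shown here alone, is what would happen if the fluorines on the core gave way to chlorine or to hydrogen.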